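A few compounds are considered here, and "the series" means these few. Any claim that something is new, unique, unknown or untested is made for them only; others in the source may bear on it.

Measured compounds:
Compound 1, `CSc1nn(-c2ccc([N+](=O)[O-])cc2)c2nc(Nc3ccccc3)n(-c3ccccc3)c(=O)c12`, gives 26.6% in a functional assay on the whole organism (strain Wistar albino) for inhibition, with Rattus norvegicus as the target, read by paw edema, with a stated time of 3 h, at a dose of 25 mg/kg by the oral route; on this read-out higher numbers stand for more inhibition at the one dose given (going by the name of the read-out) and lower numbers for less inhibition.
Compound 2, `CSc1nn(-c2ccc(S(N)(=O)=O)cc2)c2nc(Nc3ccccc3)n(-c3ccccc3)c(=O)c12`, gives 35.2% in this assay.
Compound 3, `O=c1c2c(Nc3ccccc3)nn(-c3ccc([N+](=O)[O-])cc3)c2nc(Nc2ccccc2)n1-c1ccccc1`, gives 14.1% in this assay.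

Compound 2 differs from compound 1 in one place: sulfamoyl in place of nitro on an aromatic carbon. This change brought a step of a number 8.6 percentage points higher from compound 1 to compound 2 (within the scatter), which is a small movement and cannot be separated from the usual scatter of this kind of measurement.

Compound 3 shares with compound 1 everything except one group on the core, which is the difference (anilino in place of methylsulfanyl on an aromatic carbon). Here the step was a number 12.5 percentage points lower from compound 1 to compound 3 (beyond the scatter), and compound 3 gives the lowest of the three numbers.

Compound 4, `NS(=O)(=O)c1ccc(-n2nc(Nc3ccccc3)c3c(=O)n(-c4ccccc4)c(Nc4ccccc4)nc32)cc1`, has not yet been measured. It relates to compound 3 in the way compound 2 relates to compound 1: the difference is sulfamoyl in place of nitro on an aromatic carbon, and since the words describing the place of the change are identical in both cases, this is the same change made on a core that carries anilino where compound 1 carries methylsulfanyl.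

Among the compounds with values here, only one earlier example of this change exists, and it lay within the scatter, so the expectation for compound 4 rests on a single small step. The step from compound 3 to compound 4 is expected to be about a number 7.9 percentage points higher from compound 3 to compound 4 (within the scatter), close in size to the earlier one because that earlier one was a number 8.6 percentage points higher from compound 1 to compound 2 (within the scatter). Compound 4 is therefore estimated to give about 22%, with a likely range from 10% to 34%.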

Compound 4, a percentage reported as inhibition, in the whole organism at one dose (the size of the read-out at that dose, not a potency): 39.7%
Estimate against measurement, compound 4: 17.7 percentage points below; measured number above the stated range.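

Replacing nitro with sulfamoyl on the core that carries anilino gave a number 25.6 percentage points higher from compound 3 to compound 4 (beyond the scatter) in this assay, so the size of this step did not carry over unchanged from the core that carries methylsulfanyl: the same change on two cores in this assay, a number 8.6 percentage points higher (within the scatter) from compound 1 to compound 2 and a number 25.6 percentage points higher (beyond the scatter) from compound 3 to compound 4, 17 percentage points apart, beyond the scatter of two such steps

Seen from the other side of the same four compounds, anilino in place of methylsulfanyl gave a number 4.5 percentage points higher from compound 2 to compound 4 (within the scatter) among the sulfamoyl compounds, and this step too depended on the group present elsewhere in the molecule: the same change on two cores in this assay, a number 12.5 percentage points lower (beyond the scatter) from compound 1 to compound 3 and a number 4.5 percentage points higher (within the scatter) from compound 2 to compound 4, 17 percentage points apart, beyond the scatter of two such steps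

Within the data shown here, this shows that, in this small set, the step from one change cannot simply be added to the step from the other, but it does not show why the steps differ or how either change would behave on a third core, as the four compounds give only one such comparison, at a single dose and a single time.

The compounds shown leave open whether a carboxylic acid or a methylsulfonyl group in place of sulfamoyl would give a similar number on the core that carries anilino. They also leave open what an amine or a longer chain would give in place of anilino or methylsulfanyl, and how any of these numbers would move at other doses.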